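Working notes: one methoxy step in the series

The compounds below may be only part of what the source reports. "The series", "measured", "known", "first", "only" and "open" are said of these compounds alone.

Measured so far:
compound 1 `COc1cc(Nc2nc3ccccc3nc2S(=O)(=O)c2ccccc2)cc(OC)c1OC` – > 50000 nM
compound 2 `COc1ccc(S(=O)(=O)c2nc3ccccc3nc2Nc2cc(OC)c(OC)c(OC)c2)cc1` – > 50000 nM
compound 3 `COc1cc(Nc2nc3ccccc3nc2S(=O)(=O)c2ccc(F)cc2)cc(OC)c1` – 3930 nM
Not yet measured: compound 4 `COc1cc(Nc2nc3ccccc3nc2S(=O)(=O)c2ccc(F)cc2)cc(OC)c1OC`.

In a functional assay on HCT-116 cells (Homo sapiens) for cytotoxicity, read by MTT assay, with a stated time of 72 h (on this read-out higher numbers stand for weaker inhibition and lower numbers for stronger inhibition), compound 1 gives only a limit, > 50000 nM. Compound 2 likewise gives only a limit in this assay, > 50000 nM. Among the measured compounds shown here, compound 3 is the one member with a number in this assay, 3930 nM. The other two values shown are limits, as noted under (the limit of > 50000 nM in this assay, at which 2 of the 3 values shown sit). The step from compound 1 to compound 2 is a step that the two limits leave unreadable from compound 1 to compound 2, so it reads as nothing usable.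

Compound 4 differs from compound 3 by methoxy in place of hydrogen on an aromatic carbon. For the measured compounds named here, no measured step in this assay covers that same change, so nothing quantitative carries over. What is shown is that the two compounds carrying the same trimethoxy pattern as compound 4, compound 1 and compound 2, both sit at the limit, though each also differs from compound 4 elsewhere. On that basis a loss of potency is expected, with a fair chance of a limit again. Compound 4 is estimated at 20000 nM, range 4000 nM to 80000 nM; the expected step from compound 3 to compound 4 is a 5.1-fold higher number from compound 3 to compound 4 (0.71 log units; beyond the scatter).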

Compound 4, half-maximal inhibitory concentration: 3110 nM
Compound 4: middle estimate off by 6.4-fold (0.81 log units), on the high side; measured number below the stated range.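

In this assay, methoxy in place of hydrogen on the carbon ortho to two methoxy groups gives a 1.3-fold lower number from compound 3 to compound 4 (0.10 log units; within the scatter), so this position takes the added methoxy with no readable change. The trimethoxy pattern alone therefore does not go with a limit: with that pattern kept, fluoro in place of hydrogen gives an at least 16-fold lower number from compound 1 to compound 4 (1.20 log units; beyond the scatter), and fluoro in place of methoxy gives an at least 16-fold lower number from compound 2 to compound 4 (1.20 log units; beyond the scatter). Both large steps lie at the aromatic carbon that carries fluoro in compound 4, and their full size stays unread: the limit of > 50000 nM in this assay, at which 2 of the 4 values shown sit.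

Going by these compounds, whether the carbon ortho to two methoxy groups accepts anything other than hydrogen or methoxy, such as an amine or a longer chain, remains open. Also open, on these data alone, is whether fluoro is needed at its carbon, or whether chloro or a carboxylic acid there would serve as well.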